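From benzyl to tert-butoxycarbonyl on a ring nitrogen

A few compounds are considered here, and "the series" means these few. Any claim that something is new, unique, unknown or untested is made for them only; others in the source may bear on it.

Measured in a functional assay on A549 cells (Homo sapiens) for antiproliferative activity, read by MTT assay, with a stated time of 48 h; a higher number here means a weaker inhibitor, a lower number a stronger inhibitor:
Compound 1 `Oc1ccc2cc1Oc1ccc(cc1)CCc1ccc(CN3CCN(Cc4ccccc4)CC3)c(O)c1-c1ccc(cc1O)CC2`: > 20000 nM, a limit
Compound 2 `CCCCN(CCCC)Cc1ccc2c(c1O)-c1ccc(cc1O)CCc1ccc(O)c(c1)Oc1ccc(cc1)CC2`: > 20000 nM, a limit

Compound 1 gives no number, only a limit, and stands at the limit of > 20000 nM in this assay, at which 2 of the 2 values shown sit. Compound 3 `CC(C)(C)OC(=O)N1CCN(Cc2ccc3c(c2O)-c2ccc(cc2O)CCc2ccc(O)c(c2)Oc2ccc(cc2)CC3)CC1` carries tert-butoxycarbonyl in place of benzyl on an amine nitrogen in a ring. Among the measured compounds shown here, no measured pair shows what this swap does in this assay. The expectation rests only on compound 1 and compound 2 both sitting at the limit of > 20000 nM in this assay, at which 2 of the 2 values shown sit. The expected change is a step that the limit leaves unreadable from compound 1 to compound 3, with no clear direction and nothing beyond the usual scatter. The estimate for compound 3 is 22000 nM, with an expected range from 9000 nM to 50000 nM.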

Compound 3, half-maximal inhibitory concentration: > 20000 nM
Compound 3: only a limit was reported; the forecaster's own chance of this, stated with the estimate: 70%; the middle value lies beyond the limit too.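

Compound 3 gives only a limit, as compound 1 does, so the swap of benzyl for tert-butoxycarbonyl between them cannot be read: the limit of > 20000 nM in this assay, at which 3 of the 3 values shown sit. On these data alone, whether any group on this ring nitrogen can bring measurable activity stays open.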